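A few compounds are considered here, and "the series" means these few. Any claim that something is new, unique, unknown or untested is made for them only; others in the source may bear on it.

Measured so far:
compound 1, `COc1cc(-c2cc(/C=C/C(=O)c3ccc(N)cc3)[nH]n2)cc(OC)c1OC`: 90%
compound 2, `COc1ccc(C(=O)/C=C/c2cc(-c3cc(OC)c(OC)c(OC)c3)n[nH]2)cc1OC`: 94%

In a functional assay on M14 cells (Homo sapiens) for cytotoxicity, read by sulforhodamine B assay, with a stated time of 48 h, tested at 1 uM (a higher number here means a weaker effect of the compound at the concentration tested, a lower number a stronger effect), compound 1 gives 90% and compound 2 gives 94%. Both numbers sit near the top of the scale, so neither compound shows much effect at the concentration tested. Going by the values given here, the one measured step, a number 4 percentage points higher from compound 1 to compound 2 (within the scatter), replaces the whole ring on the carbonyl carbon and still leaves the two numbers indistinguishable; compound 2 therefore cannot be ranked against compound 1, and both are best described as inactive here.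

Compound 3, `COc1ccc(C(=O)/C=C/c2cc(-c3cc(OC)c(OC)c(OC)c3)n[nH]2)cc1`, is the next member. It differs from compound 2 by hydrogen in place of methoxy on an aromatic carbon, the same ring that was exchanged in the measured step. Among the compounds with values here, that step, though it was a larger exchange than the loss of a single methoxy, moved the number only within the scatter, and the series so far offers no example of a change on that ring that shifted the read-out. On this basis no step beyond the scatter is expected: a number 2 percentage points lower from compound 2 to compound 3 (within the scatter). Compound 3 is thus estimated at 92%, with a range of 80% to 102%.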

Compound 3, a percentage reported as activity, at one concentration (the size of the read-out at that concentration, not a potency): 99%
Beside the measured number, compound 3's estimate is 7 percentage points below it, within the range that was stated.
By their numbers in this assay, from the lowest: compounds 1, 2 and 3 (each within the scatter of the next).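

In this assay, removing one methoxy to turn 3,4-dimethoxyphenyl into 4-methoxyphenyl gives a number 5 percentage points higher from compound 2 to compound 3 (within the scatter) and so leaves the read-out unchanged at this position, whether it carries methoxy or hydrogen. Exchanging the amino group of the 4-aminophenyl ring for methoxy gives a number 9 percentage points higher from compound 1 to compound 3 (within the scatter) and is likewise no readable change, so the three groups on the carbonyl carbon now form a set in which neither a whole-ring exchange nor a single-group change separates the compounds, with all three numbers near the top of the scale. No measured information bears on why this ring makes so little difference to the read-out.

As far as these compounds go, what stays open is whether any change on this ring can lower the number at all, for instance fluorine or a carboxylic acid in place of the methoxy, or a longer chain such as ethoxy. Also open, from the compounds shown here alone, is whether the same lack of separation holds at concentrations higher than the single one used in this assay or when the 3,4,5-trimethoxyphenyl group on the other side of the core is changed.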